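Chlorine for Fluorine on the Sulfonyl Aryl Group

This account rests on a few compounds, and the source may have more. Where it says the series, first, only, none or still open, it means among the compounds named here.

Compound 1 `CN1CCC(n2cc(S(=O)(=O)c3ccccc3F)c3cccnc32)C1`: 69%
Compound 2 `CN1CCC(n2cc(S(=O)(=O)c3ccccc3Cl)c3cccnc32)C1`: 91%

Both compounds were tested in a functional assay on HeLa cells for antagonist activity at 5-hydroxytryptamine receptor 6 (Homo sapiens), read by cAMP accumulation and immunoassay; on this read-out higher numbers stand for larger maximal responses and lower numbers for smaller maximal responses. Compound 1 stands lowest of the two numbers. For the measured compounds named here, the only measured step is a number 22 percentage points higher from compound 1 to compound 2 (beyond the scatter), brought about by chloro in place of fluoro on an aromatic carbon.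

Compound 3 `CN1CCC(n2cc(S(=O)(=O)c3cccc(Cl)c3)c3cccnc32)C1` differs from compound 1 as follows: 3-chlorophenyl in place of 2-fluorophenyl on a sulfonyl sulfur. The measured step changes only the halogen, whereas here a whole 3-chlorophenyl replaces the 2-fluorophenyl, so that step bears on it only in part. A rise of modest size is nevertheless expected, a number 11 percentage points higher from compound 1 to compound 3 (beyond the scatter). Compound 3 is estimated at 80%, within a range from 62% to 98%.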

Compound 3, largest response reached (reported as percent of maximum), in percent of the reference or control that the assay uses: 85%
Compound 3: the middle estimate sits 5 percentage points below what was measured; measured number inside the range.
By their numbers in this assay, from the lowest: compound 1; then compounds 3 and 2 (each within the scatter of the next).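

The change to 3-chlorophenyl gives a number 16 percentage points higher from compound 1 to compound 3 (beyond the scatter) so a chlorophenyl group again reads higher than 2-fluorophenyl on the sulfonyl sulfur. Between the two chlorophenyl groups there is a number 6 percentage points lower from compound 2 to compound 3 (within the scatter) so these two compounds do not separate by where the chlorine sits on the ring. No measurement at hand explains either result. Still open, as far as these compounds go, is how 3-fluorophenyl would compare, which would show whether the halogen or its place matters in the step from compound 1. Also open, from the compounds shown here alone, is whether a methoxy group on the ring could stand in for chlorine.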